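The compounds below may be only part of what the source reports. "The series", "measured", "known", "first", "only" and "open" are said of these compounds alone.

Working notes on the series in a functional assay on MDA-MB-231 cells (Homo sapiens) for antiproliferative activity, with a stated time of 4 days; on this read-out lower numbers stand for stronger inhibition and higher numbers for weaker inhibition. Compound 1 `CCCCc1ccc2[nH]c(-c3ccc(OC)cc3)c(C=C(C#N)C#N)c2c1` gives 26 nM, compound 2 `CCCCc1ccc2[nH]c(-c3ccc(C)cc3)c(C=C(C#N)C#N)c2c1` gives 65 nM, and compound 3 `CCCCc1ccc2[nH]c(-c3ccc(C(F)(F)F)cc3)c(C=C(C#N)C#N)c2c1` gives 56 nM. Among these numbers, the nearest neighbour of compound 3 lies within the scatter, with a 1.2-fold lower number from compound 2 to compound 3 (0.06 log units; within the scatter). Its furthest neighbour is separated by a 2.2-fold higher number from compound 1 to compound 3 (0.33 log units; beyond the scatter), a modest step of similar size to a 2.5-fold higher number from compound 1 to compound 2 (0.40 log units; beyond the scatter).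

The next structure, compound 4 `CCCCCCc1ccc2[nH]c(-c3ccc(C(F)(F)F)cc3)c(C=C(C#N)C#N)c2c1`, keeps the trifluoromethyl group and changes the chain: ethyl in place of hydrogen on a saturated chain carbon, four bonds along the chain from an aromatic carbon. Within the data shown here, none of the measured steps touches that chain. All three exchange methoxy, methyl or trifluoromethyl on an aromatic carbon, so they serve only as a rough guide to the size of steps in this small set and give no direction for the new change. The data hold no measured chain change, so the working expectation in this assay is no step beyond the scatter, with a modest step in either direction left open. The estimated change is a 1.3-fold higher number from compound 3 to compound 4 (0.10 log units; within the scatter). Compound 4 is expected at 70 nM, with an estimated range of 25 nM to 190 nM.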

Compound 4, half-maximal inhibitory concentration: 150 nM
The estimate for compound 4 lay 2.1-fold (0.33 log units) below the measured number, and the stated range covers the measured number.
By their numbers in this assay, from the lowest: compound 1; then compounds 3 and 2 (each within the scatter of the next); then compound 4.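

In this assay, ethyl in place of hydrogen on a saturated chain carbon, four bonds along the chain from an aromatic carbon, gives a 2.7-fold higher number from compound 3 to compound 4 (0.43 log units; beyond the scatter). Among these compounds, this is the first measured change on the chain, and it shows that the chain is not a silent part of the series: the step lies beyond the scatter and points toward weaker inhibition, a direction that the exchanges of methoxy, methyl and trifluoromethyl on an aromatic carbon could not give for this position. The reading rests on a single pair with trifluoromethyl held constant, and no measured information bears on why the number rises.

The compounds shown leave open whether the rise continues with a longer chain, or whether an amine or a carboxylic acid at the end of the chain would behave differently from the plain carbon chain. They also leave open whether the same ethyl change gives a step of similar size and direction on compound 1, which carries methoxy on the aromatic carbon in place of trifluoromethyl.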